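The source may hold more compounds than are shown below. What is called first, only, known or untested is meant among the compounds shown, and "the series" means these compounds.

Two compounds have been measured so far in a physicochemical assay for solubility (on this read-out lower numbers stand for lower solubility and higher numbers for higher solubility), as follows:

compound 1 `CC(C)C[C@@H]1NC(=O)[C@H](C(C)C)N(C)C(=O)[C@@H](CC(C)C)NC(=O)[C@@H](Cc2ccccc2)NC(=O)[C@@H](C(c2ccccc2)c2ccccc2)NC1=O` gives 2100 ug/mL
compound 2 `COc1ccc(C[C@H]2NC(=O)[C@@H](C(c3ccccc3)c3ccccc3)NC(=O)[C@H](CC(C)C)NC(=O)[C@H](C(C)C)N(C)C(=O)[C@@H](CC(C)C)NC2=O)cc1` gives 1500 ug/mL

Compound 2 stands within the scatter of compound 1, so the two numbers cannot be told apart. Compound 3 `CC(C)C[C@@H]1NC(=O)[C@H](C(C)C)N(C)C(=O)[C@@H](CC(C)C)NC(=O)[C@@H](Cc2cscn2)NC(=O)[C@@H](C(c2ccccc2)c2ccccc2)NC1=O` differs from compound 2 by 1,3-thiazol-4-yl in place of 4-methoxyphenyl on a saturated chain carbon bound to a saturated ring carbon and so carries 1,3-thiazol-4-yl in place of 4-methoxyphenyl on a saturated chain carbon bound to a saturated ring carbon. Within the data shown here, only one measured step bears on this, and only in part: a 1.4-fold lower number from compound 1 to compound 2 (0.15 log units; within the scatter) came with methoxy in place of hydrogen on an aromatic carbon. Among the measured compounds shown here, no measured compound carries 1,3-thiazol-4-yl, so the exchange itself is untested. Compound 3 lacks the methoxy, as does compound 1 at 2100 ug/mL in this assay so the expectation leans toward that number. The expected move is a 1.3-fold higher number from compound 2 to compound 3 (0.10 log units; within the scatter) and thus no step beyond the scatter. For compound 3 the estimated value is 1900 ug/mL with an expected range from 900 ug/mL to 4000 ug/mL for now.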

Compound 3, solubility: 9500 ug/mL
The estimate for compound 3 lay 5.0-fold (0.70 log units) below the measured number; measured number outside the range, above it.
By their numbers in this assay, from the lowest: compounds 2 and 1 (each within the scatter of the next); then compound 3.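

In this assay the place on a saturated chain carbon bound to a saturated ring carbon turns out to carry steps beyond the scatter, which the methoxy exchange alone had not shown. Putting 1,3-thiazol-4-yl in place of 4-methoxyphenyl gives a 6.3-fold higher number from compound 2 to compound 3 (0.80 log units; beyond the scatter) and putting it in place of phenyl gives a 4.5-fold higher number from compound 1 to compound 3 (0.66 log units; beyond the scatter), so the rise goes with replacing the six-membered carbon ring, with or without its methoxy. Nothing measured here accounts for this rise.

Going by these compounds, whether it follows the ring nitrogen, the sulfur or the five-membered ring as a whole remains open. So does whether a pyridin-3-yl ring, an imidazol-4-yl ring or a simple amine at this same place would go the same way.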